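The source may hold more compounds than are shown below. What is called first, only, known or untested is meant among the compounds shown, and "the series" means these compounds.

Compound 2 `CNCc1ccc(Cl)c(-c2ccccc2OC)c1` and compound 1 `COc1ccccc1-c1cc(C2CCNC2)ccc1Cl` share the same core and differ only in the group carrying the amine. In a functional assay on HEK293 cells for agonist activity at 5-hydroxytryptamine receptor 7 (Homo sapiens), read by a luciferase reporter and beta-arrestin recruitment, with a stated time of 22 h (a lower number here means a smaller maximal response, a higher number a larger maximal response), compound 1 gives 54%, while compound 2 gives 61%, a step of a number 7 percentage points higher from compound 1 to compound 2 (within the scatter) that is within the scatter, so the two values cannot be ordered. Within the data shown here, compound 2 therefore stands on one of only two numbers, and the nearest, compound 1, is indistinguishable from it. Compound 3 `COc1ccccc1-c1cc(CN(C)C)ccc1Cl` is the next member. The change from compound 2 to compound 3 is methyl in place of hydrogen on an amine nitrogen, sitting on an amine nitrogen whose other neighbours are two saturated chain carbons. Among the measured compounds shown here, the one measured step touches the same amine region, but with a different change, and it was within the scatter; no step on the amine nitrogen itself has been seen. Compound 3 is therefore expected to show a step of a number 1 percentage points lower from compound 2 to compound 3 (within the scatter) that stays within the scatter. The estimated value for compound 3 in this assay is 60%, between 45% and 75%.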

Compound 3, largest response reached (Emax), in percent of the reference or control that the assay uses: 43%
Compound 3: middle estimate off by 17 percentage points, on the high side; measured number outside the range, below it.
By their numbers in this assay, from the lowest: compound 3; then compounds 1 and 2 (each within the scatter of the next).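

Methyl in place of hydrogen on an amine nitrogen is the first change seen on that nitrogen itself, and in this assay it gives a number 18 percentage points lower from compound 2 to compound 3 (beyond the scatter), a step that the earlier amine-region change did not show. Replacing pyrrolidin-3-yl on an aromatic carbon with (dimethylamino)methyl likewise gives a number 11 percentage points lower from compound 1 to compound 3 (beyond the scatter), whereas replacing it with (methylamino)methyl gave a number 7 percentage points higher from compound 1 to compound 2 (within the scatter), so among these compounds the methyl on the amine nitrogen is what separates compound 3 from compound 2. No measurement is at hand that explains this step.

The compounds shown leave open where a primary aminomethyl group or an ethyl group on the amine nitrogen would fall. They also leave open whether a methyl on the pyrrolidine nitrogen of compound 1 would give a similar step.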